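The compounds below may be only part of what the source reports. "The series", "measured", "known", "first", "only" and "open" are said of these compounds alone.

Four compounds share one core, a thiadiazole bearing a pyridine ring and a thioether-linked acetamide, and differ only in the group on the amide nitrogen. Compound 1 is `O=C(CSc1nnc(-c2ccncc2)s1)Nc1ccc(Cl)cc1`, compound 2 is `O=C(CSc1nnc(-c2ccncc2)s1)NCc1ccccc1Cl`, compound 3 is `O=C(CSc1nnc(-c2ccncc2)s1)Nc1c(Cl)cccc1Cl`, and compound 4, still to be measured, is `O=C(CSc1nnc(-c2ccncc2)s1)NCc1ccc(Cl)cc1`.

The read-out is an ADME assay on BHK-21 cells (Mesocricetus auratus) for cytotoxicity, with a stated time of 3 days; a higher number here means that more compound is tolerated, a lower number that less compound is tolerated. In this assay compound 1 reaches only a limit, > 50000 nM, so no single number is available for it. For compound 2 this assay gives "not determined" (no result reported). For compound 3 this assay gives "not determined" (no result reported), so it has no number of its own either. The one limit of this assay among these compounds is that of compound 1, summarised as the limit of > 50000 nM in this assay, at which 1 of the 3 values shown sits.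

Moving from compound 3 to compound 4 means (4-chlorobenzyl in place of 2,6-dichlorophenyl on an amide-type nitrogen). Within the data shown here, since no measured pair of compounds here differs in a single place, no measured step exists to set the size of this change; the only figure available is the limit of compound 1, and on that basis the expectation is for no shift beyond the usual scatter, with the measurement likely to end at the same limit.

Compound 4 is expected in this assay to give about 50000 nM, within a range from 20000 nM to 100000 nM.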

Compound 4, half-maximal cytotoxic concentration: > 50000 nM
Compound 4 ended at the assay's limit; the forecaster's own chance of this, stated with the estimate: 70%; the middle value sits exactly at the limit.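

In this assay, compound 1 and compound 4 both stop at the same limit of the assay, so the step from 4-chlorophenyl to 4-chlorobenzyl on an amide-type nitrogen cannot be read: the limit of > 50000 nM in this assay, at which 2 of the 4 values shown sit. The compounds shown leave open whether any group at this place changes how much compound the cells tolerate.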